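Notes on Amide Variation in the Shared Core

The compounds below may be only part of what the source reports. "The series", "measured", "known", "first", "only" and "open" are said of these compounds alone.

Measured so far, in an assay on HEK293 cells for agonist activity at Toll-like receptor 8 (Homo sapiens), read by a luciferase reporter, with a stated time of 6 h; on this read-out lower numbers stand for an effect already at smaller amounts and higher numbers for an effect only at larger amounts of compound:
compound 1 `CCCCNc1nc(N)nc2c1CN(C(=O)c1ccccn1)CC2` gives 2.9 uM
compound 2 `CCCCNc1nc(N)nc2c1CN(C(=O)c1csc(N)n1)CC2` gives 6.9 uM

Compound 2 has the higher of the two numbers in this assay; the nearest point is compound 1, and the step of a 2.4-fold higher number from compound 1 to compound 2 (0.38 log units; beyond the scatter) lies beyond the scatter but is modest.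

Compound 3 `CCCCNc1nc(N)nc2c1CN(C(=O)c1csnn1)CC2` is the next point. Its difference from compound 2 is 1,2,3-thiadiazol-4-yl in place of 2-amino-1,3-thiazol-4-yl on a carbonyl carbon.

Among the compounds with values here, only one measured step bears on this change: the earlier swap of the group on the carbonyl carbon, a 2.4-fold higher number from compound 1 to compound 2 (0.38 log units; beyond the scatter), which moved the number modestly. That step involved a different pair of groups, so it sets the size but not the direction to expect. A small step in this assay is therefore expected, in either direction, possibly none beyond the scatter.

Compound 3 is estimated at 5 uM, range 2 uM to 15 uM, which corresponds to an expected step of a 1.4-fold lower number from compound 2 to compound 3 (0.14 log units; within the scatter).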

Compound 3, minimum effective concentration: 0.1 uM
Compound 3: the middle estimate sits 50-fold (1.70 log units) above what was measured; measured number outside the range, below it.
By their numbers in this assay, from the lowest: compound 3; then compound 1; then compound 2.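

In this assay, the group on the carbonyl carbon can move the number much further than the earlier modest step suggested: a 69-fold lower number from compound 2 to compound 3 (1.84 log units; beyond the scatter) is large, and a 29-fold lower number from compound 1 to compound 3 (1.46 log units; beyond the scatter) is also large. Compound 3 therefore has the lowest number of the three, with both of its steps beyond the scatter. The change replaces one five-membered aromatic ring with another, going from 2 hetero atoms to 3 and from 1 hydrogen-bond donor to 0, but no measurement here ties the step to either difference.

The three groups shown leave open whether the amino group or the ring's hetero atoms matter more. An unsubstituted 1,3-thiazol-4-yl group would separate the two, while a 1,3,4-thiadiazol-2-yl group would test whether the arrangement of ring atoms matters.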